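The source may hold more compounds than are shown below. What is called first, only, known or untested is meant among the compounds shown, and "the series" means these compounds.

Working notes on the series. Compound 1 `CCCC(=O)c1ccc(OCCCCOc2cccc(C(=O)O)c2C)c(C)c1O` has been tested in an assay on HEK293 cells for positive allosteric modulation of metabotropic glutamate receptor 3 (Rattus norvegicus), read by thallium flux, with a stated time of 2.5 min (on this read-out higher numbers stand for larger maximal responses and lower numbers for smaller maximal responses), where compound 1 gives 53%. Compound 2 `Cc1c(OCCCCOc2ccc(C(=O)O)cc2)ccc(C(=O)CC(C)C)c1O` gives 51.9% in this assay, and compound 3 `Cc1ccc(C(=O)O)cc1OCCCCOc1ccc(C(=O)CC2CCCC2)c(O)c1C` gives 26.9%. Compound 1 stands highest of the three numbers, but the value of compound 2 lies within the usual scatter of it, so the two cannot be ranked against each other; the value of compound 3 lies beyond the scatter and is clearly the lowest of the set. Going by the values given here, no step between two measured compounds that differ in one place is available, as the measured compounds differ from one another in several places at once.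

Compound 4 `CCC(=O)c1ccc(OCCCCOc2cccc(C(=O)O)c2C)c(C)c1O` is still to be measured in this assay. Its difference from compound 1 is hydrogen in place of methyl on a saturated chain carbon, two bonds along the chain from a carbonyl carbon, that is, propylcarbonyl to propanoyl. Among the compounds with values here, no measured pair isolates this change. The step is expected to be small and a number 5 percentage points lower from compound 1 to compound 4 (within the scatter) is estimated to stay within the scatter, with no firm direction. Compound 4 is therefore expected to give about 48% in this assay, with a range from 30% to 65%.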

Compound 4, largest response reached (reported as percent of maximum), in percent of the reference or control that the assay uses: 16.3%
The estimate for compound 4 lay 31.7 percentage points above the measured number; the measured number lies below the stated range.
By their numbers in this assay, from the lowest: compound 4; then compound 3; then compounds 2 and 1 (each within the scatter of the next).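

In this assay, going by these compounds alone, the change from propylcarbonyl to propanoyl gives a number 36.7 percentage points lower from compound 1 to compound 4 (beyond the scatter) and is the only step that isolates a single place. The response of this core is thus sensitive to one methyl on a saturated chain carbon, two bonds along the chain from a carbonyl carbon, and this single-place change moves the number beyond the scatter. Nothing measured here accounts for the size of this step.

As far as these compounds go, whether a longer chain at this place, such as pentanoyl, restores or further changes the response remains open, as does the effect of a branched chain on the core of compound 1. From the compounds shown here alone, whether the step keeps its size with the carboxylic acid placed as in compound 2 is also open.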